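Dropping the Bromo Group: From Compound 1 to Compound 3

The compounds below may be only part of what the source reports. "The series", "measured", "known", "first", "only" and "open" are said of these compounds alone.

Within the data shown here, compound 1 `Cc1nc2ccccc2n1-c1csc(Nc2ccc(Br)cc2)n1` is the more potent of the two compounds measured so far. In a functional assay on RKO cells (Homo sapiens) for cytotoxicity, read by resazurin assay, with a stated time of 72 h (on this read-out lower numbers stand for stronger inhibition and higher numbers for weaker inhibition), compound 1 gives 90 nM. Its only measured companion, compound 2 `Cc1nccn1-c1csc(Nc2ccccc2)n1`, differs from it in more than one place and in this assay compound 2 gives 32500 nM, a gap far beyond the scatter; how much of that gap belongs to each change cannot be told from these two numbers alone.

Compound 3 `Cc1nc2ccccc2n1-c1csc(Nc2ccccc2)n1` has not yet been measured. The change from compound 1 to compound 3 is hydrogen in place of bromo on an aromatic carbon. Among the measured compounds shown here, no measured pair isolates this change, so its size is uncertain. The writer expects a loss of potency for compound 3, a step of a 10-fold higher number from compound 1 to compound 3 (1.00 log units; beyond the scatter), of moderate size rather than the whole gap seen to compound 2. The expected value for compound 3 in this assay is 900 nM, within a range from 200 nM to 4000 nM.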

Compound 3, half-maximal inhibitory concentration: 40000 nM
Estimate against measurement, compound 3: 44-fold (1.65 log units) below, outside the stated range (above it).
By their numbers in this assay, from the lowest: compound 1; then compounds 2 and 3 (each within the scatter of the next).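

Taken alone, the removal of the bromo group, on an aromatic carbon para to a large group, moves this assay by a 440-fold higher number from compound 1 to compound 3 (2.65 log units; beyond the scatter), a large step that the two earlier compounds could not isolate. The 4-bromophenyl to phenyl change therefore matters greatly on the core of compound 1, and with the bromine gone, compound 3 stands within the scatter of compound 2. The compounds shown give no account of why this single atom carries so large a step.

From the compounds shown here alone, it remains open whether the effect is particular to bromine or would also appear with another group at the same place, such as chloro, methyl, methoxy or an amine. Also open, going by these compounds, is whether bromo would give a similar step on the core of compound 2.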